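The source may report more compounds than this note shows. Statements on the series, on what has been measured and on what is new or still open speak of the compounds shown alone.

Measured so far:

Compound 1 `N#Cc1c(Cl)nc(SCC(=O)Nn2c(COc3ccc(Cl)cc3Cl)nc3ccccc3c2=O)nc1-c1ccc(Cl)cc1`: 61.5%
Compound 2 `N#Cc1c(Nc2ccccc2)nc(SCC(=O)Nn2c(COc3ccc(Cl)cc3Cl)nc3ccccc3c2=O)nc1-c1ccc(Cl)cc1`: 36.5%
Compound 3 `N#Cc1c(Nc2ccc(Cl)cc2)nc(SCC(=O)Nn2c(COc3ccc(Cl)cc3Cl)nc3ccccc3c2=O)nc1-c1ccc(Cl)cc1`: 46.2%

In a functional assay on the whole organism (strain albino) for inhibition, with Rattus norvegicus as the target, read by paw edema, with stated times of 1 h and 0.5 h, at a dose of 100 mg/kg by the oral route (on this read-out higher numbers stand for more inhibition at the one dose given (going by the name of the read-out) and lower numbers for less inhibition), compound 1 gives 61.5%, the top of the three. The steps from it are both downward: a number 25 percentage points lower from compound 1 to compound 2 (beyond the scatter), a number 15.3 percentage points lower from compound 1 to compound 3 (beyond the scatter). Compound 3 sits second of the three, but its gap to compound 2 is within the scatter: a number 9.7 percentage points higher from compound 2 to compound 3 (within the scatter). Only its gap to compound 1 is beyond the scatter.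

Compound 4 `N#Cc1c(Nc2ccc(O)cc2)nc(SCC(=O)Nn2c(COc3ccc(Cl)cc3Cl)nc3ccccc3c2=O)nc1-c1ccc(Cl)cc1` is not yet measured. It differs from compound 3 in one place: hydroxy in place of chloro on an aromatic carbon. Among the compounds with values here, the one measured step that bears on this spot is the one that placed chloro there, a number 9.7 percentage points higher from compound 2 to compound 3 (within the scatter), which stayed within the scatter. Replacing that chloro by hydroxy is therefore expected to move this assay by little, and no step beyond the scatter is expected in either direction.

For compound 4 the estimated step is a number 3.2 percentage points lower from compound 3 to compound 4 (within the scatter). Compound 4 is expected to give about 43%, within a range of 28% to 58%.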

Compound 4, a percentage reported as inhibition, in the whole organism at one dose (the size of the read-out at that dose, not a potency): 71.2%
For compound 4 the middle estimate is 28.2 percentage points below the measured one; measured number above the stated range.
By their numbers in this assay, from the lowest: compounds 2 and 3 (each within the scatter of the next); then compounds 1 and 4 (each within the scatter of the next).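

The aromatic carbon where chloro and hydrogen could not be told apart does respond to the group placed on it in this assay once that group is hydroxy, since a number 25 percentage points higher from compound 3 to compound 4 (beyond the scatter) and a number 34.7 percentage points higher from compound 2 to compound 4 (beyond the scatter) are both beyond the scatter. Replacing the chloro of compound 1 by an arylamino group therefore need not cost activity, as a number 9.7 percentage points higher from compound 1 to compound 4 (within the scatter) shows for (4-hydroxyphenyl)amino, unlike the two other amino groups shown. No measurement at hand bears on why hydroxy behaves differently from chloro and hydrogen here.

Going by these compounds, whether the gain needs the free hydroxy remains open, and a methoxy, an amine or a carboxylic acid on the same carbon would test that. Also open, on these data alone, is whether hydroxy would act alike on another carbon of that phenyl ring.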